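Fluoro to chloro: cytotoxicity notes on the series

This account rests on a few compounds, and the source may have more. Where it says the series, first, only, none or still open, it means among the compounds named here.

Measured so far in an ADME assay on MDBK cells (Bos taurus) for cytotoxicity (on this read-out higher numbers stand for lower toxicity in this test and lower numbers for higher toxicity in this test), for two compounds:
- Compound 1 `Fc1cccc(F)c1Cn1ccc2nc(-c3ccccc3)nc-2c1` gives > 100000 nM as a limit of the assay
- Compound 2 `Fc1ccc(Cn2ccc3nc(-c4ccccc4)nc-3c2)cc1` gives > 100000 nM as a limit of the assay

Compound 2 stands at > 100000 nM as a limit of the assay and not a number. The next compound is compound 3 `Clc1ccc(Cn2ccc3nc(-c4ccccc4)nc-3c2)cc1` and the change to it is chloro in place of fluoro on an aromatic carbon with chloro in place of fluoro on an aromatic carbon. Going by the values given here, the one measured step (a step that the two limits leave unreadable from compound 1 to compound 2) offers no size to carry over to this change. Among the compounds with values here, the remaining evidence is the limit of > 100000 nM in this assay, at which 2 of the 2 values shown sit, and it shows no numerical step of any size. For compound 3 the estimated step is a number no higher from compound 2 to compound 3 (the limit leaves the size open) and none beyond the scatter is expected in this assay on this evidence. Compound 3 is estimated at 100000 nM with an expected range from 40000 nM to 200000 nM and a further limit is the likeliest report.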

Compound 3, half-maximal cytotoxic concentration: > 100000 nM
Compound 3: a limit, no number; the forecaster's own chance of this, stated with the estimate: 70%; the middle value lies on the limit itself.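

In this assay compound 3 gives > 100000 nM, a limit of the assay and not a number. Going by these compounds alone, no step among compound 1, compound 2 and compound 3 can be read. The compounds shown leave open whether the 2,6-difluorophenyl, 4-fluorophenyl and 4-chlorophenyl groups differ at all on this read-out.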